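A few compounds are considered here, and "the series" means these few. Any claim that something is new, unique, unknown or untested is made for them only; others in the source may bear on it.

Compound 1 `N=C(N)N(CCCCN1CCN(CCCCCCCOc2ccccc2)CC1)Cc1ccccc1`: 200 nM
Compound 2 `N=C(N)N(CCCCN1CCN(CCCCCCCOc2ccccc2)CC1)Cc1ccc(Cl)cc1`: 240 nM

Within the data shown here, in an assay on ileum for antagonist activity at histamine H1 receptor (Cavia porcellus), with stated times of 5 min, 30 min and 10 min (on this read-out higher numbers stand for weaker binding and lower numbers for tighter binding), compound 2 stands at the higher of the two numbers, with compound 1 as its only neighbour; the step of a 1.2-fold higher number from compound 1 to compound 2 (0.08 log units; within the scatter) lies within the scatter. Compound 3 `N=C(N)N(CCCCN1CCN(CCCCCCCOc2ccccc2)CC1)Cc1ccc(C(F)(F)F)cc1` differs from compound 2 by trifluoromethyl in place of chloro on an aromatic carbon. Among the measured compounds shown here, only that one measured step, a substituent entering on the same aromatic carbon, bears on this change, and it was within the scatter, so no movement beyond the scatter is expected in this assay. Compound 3 is therefore expected to give 300 nM, between 120 nM and 750 nM. This implies an expected step of a 1.3-fold higher number from compound 2 to compound 3 (0.10 log units; within the scatter).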

Compound 3, dissociation constant: 347 nM
For compound 3 the middle estimate is 1.2-fold (0.06 log units) below the measured one; low and high end bracket the measured number.
By their numbers in this assay, from the lowest: compounds 1, 2 and 3 (each within the scatter of the next).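

With trifluoromethyl on this aromatic carbon, para to a large group, this assay shows a 1.4-fold higher number from compound 2 to compound 3 (0.16 log units; within the scatter) and, against the unsubstituted compound, a 1.7-fold higher number from compound 1 to compound 3 (0.24 log units; within the scatter) as its second step. Both steps lie within the scatter, so this position has now taken a group of four heavy atoms, as well as a single chlorine, with no change that the assay can separate from repeat variation. Nothing on hand gives a reason for this result. As far as these compounds go, whether an amine or a carboxylic acid on this aromatic carbon would move the number beyond the scatter remains open.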